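Swapping a hydroxyethyl for a benzyl on a sulfonamide

The source may report more compounds than this note shows. Statements on the series, on what has been measured and on what is new or still open speak of the compounds shown alone.

Compound 1 `O=S(=O)(NCCO)c1cccc(Nc2ccc3nccc(-c4ccncc4)c3n2)c1` carries a sulfonamide on the shared core. Among the measured compounds shown here, in a physicochemical assay for solubility, read by HPLC, using the shake flask method, measured as kinetic solubility, with a stated time of 20 h, at pH 6.5, tested at 200 uM (on this read-out higher numbers stand for higher solubility and lower numbers for lower solubility), compound 1 gives 115000 nM, the only full number recorded among the two measured compounds. Compound 2 `Nc1cccc(-c2ccc3nccc(-c4ccncc4)c3n2)c1` has no sulfonamide and carries an amino group instead. In this assay compound 2 reaches only a limit of the assay, < 5000 nM, which is the limit of < 5000 nM in this assay, at which 1 of the 2 values shown sits. Compound 3 `O=S(=O)(NCc1ccccc1)c1cccc(Nc2ccc3nccc(-c4ccncc4)c3n2)c1`, not yet measured, differs from compound 1 in one place: phenyl in place of hydroxymethyl on a saturated chain carbon bound to a sulfonamide nitrogen. For the measured compounds named here, no measured pair shows a comparable change, so the size of this step cannot be read from the data. The step of a 7.7-fold lower number from compound 1 to compound 3 (0.88 log units; beyond the scatter) is expected to lower solubility beyond the usual scatter. Compound 3 is therefore estimated at 15000 nM in this assay, with a likely range from 3000 nM to 60000 nM.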

Compound 3, solubility: < 5000 nM
Compound 3: no number, only a limit (the forecaster's own chance of this, stated with the estimate: 30%); at least 3.0-fold (0.47 log units) between middle value and limit.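

In this assay, what sits on the sulfonamide nitrogen clearly matters: phenyl in place of hydroxymethyl on the saturated chain carbon gives an at least 23-fold lower number from compound 1 to compound 3 (1.36 log units; beyond the scatter). Compound 3 keeps the sulfonamide of compound 1, so the sulfonamide alone does not guarantee a high number on this read-out. The value of compound 3 is a limit and not a number, so the full size of this step cannot be read: the limit of < 5000 nM in this assay, at which 2 of the 3 values shown sit.

The change removes hydroxymethyl and brings in a phenyl ring in one move, so the compounds shown cannot tell whether losing the first or gaining the second counts for more. A plain ethyl chain would help separate the two, while a longer chain ending in hydroxyl, an amine or a carboxylic acid would show how much room remains at this position.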